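The source may hold more compounds than are shown below. What is called first, only, known or untested is meant among the compounds shown, and "the series" means these compounds.

- compound 1 `NC(=O)c1c(NC(=O)/C=C/c2ccccc2)sc2c1CCCC2`: 530 nM
- compound 2 `CC(C)c1ccc(/C=C/C(=O)Nc2sc3c(c2C(N)=O)CCCC3)cc1`: 2700 nM

In a functional assay on MV4-11 cells (Homo sapiens) for antiproliferative activity (on this read-out higher numbers stand for weaker inhibition and lower numbers for stronger inhibition), compound 1 has the lower of the two numbers, so it is the stronger inhibitor of this pair. Compound 3 `Cc1ccc(/C=C/C(=O)Nc2sc3c(c2C(N)=O)CCCC3)o1` differs from it by 5-methylfuran-2-yl in place of phenyl on a double-bonded chain carbon bound to a double-bonded chain carbon. Within the data shown here, only one measured step bears on this: a 5.1-fold higher number from compound 1 to compound 2 (0.71 log units; beyond the scatter), with isopropyl in place of hydrogen on an aromatic carbon. Among the measured compounds shown here, that change was made on the phenyl that compound 3 gives up, and no measured compound carries 5-methylfuran-2-yl, so the guidance is thin. A smaller move toward a higher number is expected in this assay: a 1.9-fold higher number from compound 1 to compound 3 (0.28 log units; within the scatter). For compound 3 the estimated value is 1000 nM, within an expected range of 300 nM to 3000 nM.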

Compound 3, half-maximal inhibitory concentration: 10000 nM
The estimate for compound 3 lay 10-fold (1.00 log units) below the measured number; measured number above the stated range.
By their numbers in this assay, from the lowest: compound 1; then compound 2; then compound 3.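

Replacing the whole ring on this double-bonded chain carbon, rather than adding to the phenyl, gives a 19-fold higher number from compound 1 to compound 3 (1.28 log units; beyond the scatter) in this assay. Phenyl and 5-methylfuran-2-yl have the same count of heavy atoms, so keeping that count does not keep the number in place at this position. Nothing available explains the rise. This change swaps the ring and adds a methyl together, and the compounds shown cannot separate those two parts. Plain furan-2-yl, without the methyl, would tell them apart.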